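Repositioned fluorine on the biaryl: cytotoxicity notes

A few compounds are considered here, and "the series" means these few. Any claim that something is new, unique, unknown or untested is made for them only; others in the source may bear on it.

Compound 2 `COc1cc(F)cc(-c2ccc(C(=O)N(Cc3cccc(OCCCCCC(=O)O)c3)C(C)C)cc2)c1` has been run in an ADME assay on HEK293 cells (Homo sapiens) for cytotoxicity, read by CellTiter-Glo and resazurin assay, with a stated time of 72 h (a higher number here means that more compound is needed for the effect, a lower number that less compound is needed), where compound 2 gives only an assay limit of > 26000 nM. Compound 1 `Cc1nnc(-c2cccc(-c3ccc(C(=O)N(Cc4cccc(OCCCCCC(=O)O)c4)C(C)C)cc3)c2)o1` likewise gives only a limit in this assay, namely > 26000 nM. Among the measured compounds shown here, the single neighbouring step, a step that the two limits leave unreadable from compound 1 to compound 2, is therefore unreadable; both values sit on (the limit of > 26000 nM in this assay, at which 2 of the 2 values shown sit). Compound 3 `COc1ccc(F)c(-c2ccc(C(=O)N(Cc3cccc(OCCCCCC(=O)O)c3)C(C)C)cc2)c1` differs from compound 2 by 2-fluoro-5-methoxyphenyl in place of 3-fluoro-5-methoxyphenyl on an aromatic carbon. No readable step bears on this change, so a step that the limit leaves unreadable from compound 2 to compound 3 in this assay is expected, none beyond the scatter, with a limit again the likely report. Compound 3 is estimated at 40000 nM, range 15000 nM to 200000 nM.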

Compound 3, half-maximal effective concentration: > 26000 nM
Compound 3: a limit, no number; the forecaster's own chance of this, stated with the estimate: 85%; the middle value does not contradict the limit.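

Compound 3 gives only a limit, as do compound 1 and compound 2, so no step among the three can be read: the limit of > 26000 nM in this assay, at which 3 of the 3 values shown sit.

As far as these compounds go, whether 2-fluoro-5-methoxyphenyl and 3-fluoro-5-methoxyphenyl differ at all in this assay stays open.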